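The source may hold more compounds than are shown below. What is called first, only, known or untested is meant among the compounds shown, and "the series" means these compounds.

Compound 1 `COc1cc(C)cc(-c2c(-c3ccnc(-c4ccc(C(C)=O)cc4)c3)cnn2CC#N)c1` gives 90% in a functional assay on ACHN cells (Homo sapiens) for cytotoxicity, read by sulforhodamine B assay, with a stated time of 48 h, tested at 100 nM (a lower number here means a stronger effect, a higher number a weaker effect of the compound at the concentration tested), the higher of the two numbers measured. Compound 2 `COc1cc(C)cc(-c2nn(CC#N)cc2-c2ccnc(-c3ccc(N(C)C)cc3)c2)c1`, which also carries a dimethylamino group but is built differently, gives 29% in this assay, a number beyond the scatter below compound 1. Compound 3 `COc1cc(C)cc(-c2c(-c3ccnc(-c4ccc(N(C)C)cc4)c3)cnn2CC#N)c1` differs from compound 1 in one place: dimethylamino in place of acetyl on an aromatic carbon. The expected step is a number 45 percentage points lower from compound 1 to compound 3 (beyond the scatter), a clear drop, because compound 2 with the same entering group gives 29%. Compound 3 is therefore estimated at 45%, in a range from 20% to 80%.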

Compound 3, a percentage reported as activity, at one concentration (the size of the read-out at that concentration, not a potency): 34%
The estimate for compound 3 lay 11 percentage points above the measured number, within the range that was stated.
By their numbers in this assay, from the lowest: compounds 2 and 3 (each within the scatter of the next); then compound 1.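

Compound 1 and compound 3 differ only at this aromatic carbon, so this pair isolates the change. In this assay, dimethylamino in place of acetyl gives a number 56 percentage points lower from compound 1 to compound 3 (beyond the scatter), showing that the read-out depends strongly on the group held here, even though both groups count the same number of heavy atoms. Nothing available explains why this change has such an effect. Open, going by these compounds, is how far the read-out would move with a primary amine or a carboxylic acid at this position. Among these compounds, with only two groups compared here, no wider trend can be drawn.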